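The source may report more compounds than this note shows. Statements on the series, on what has been measured and on what is new or still open speak of the compounds shown alone.

Two compounds sharing the same core were tested in a functional assay on PC-3 cells (Homo sapiens) for inhibition, read by sulforhodamine B assay, with a stated time of 48 h; on this read-out higher numbers stand for weaker inhibition of growth and lower numbers for stronger inhibition of growth. Compound 1 `CC1=CC[C@H](C(C)(C)N=C=S)CC1` is the bare core bearing an isothiocyanate group. In this assay compound 1 is reported only as > 100000 nM, which is a limit of the assay and not a number. Compound 2 `CC1=CC[C@H](C(C)(C)NC(=S)N/N=C/c2ccccc2O)CC1` attaches a 2-hydroxyphenyl ring through a longer linker. In this assay compound 2 is reported as < 40 nM, again a limit of the assay rather than a number. Of the two values shown, compound 2 therefore stands at the strong end the limit of < 40 nM in this assay, at which 1 of the 2 values shown sits, and compound 1 at the weak end (the limit of > 100000 nM in this assay, at which 1 of the 2 values shown sits). Compound 3 `CC1=CC[C@H](C(C)(C)NC(=S)N/N=C/c2ccc(Cl)cc2)CC1` has not yet been measured. It differs from compound 2 by 4-chlorophenyl in place of 2-hydroxyphenyl on a carbon with a double bond to nitrogen. Within the data shown here, no measured pair shows the effect of such a swap, so the expected step from compound 2 to compound 3, an at least 2.0-fold higher number from compound 2 to compound 3 (0.30 log units; that floor lies within the scatter), is a modest loss that may not exceed the usual scatter. Compound 3 is therefore estimated at 80 nM in this assay, with a likely range from 15 nM to 600 nM.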

Compound 3, concentration for 50% growth inhibition: 50 nM
Compound 3: the middle estimate sits 1.6-fold (0.20 log units) above what was measured; the range from low to high includes it.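

The 2-hydroxyphenyl group on a carbon with a double bond to nitrogen can be replaced by 4-chlorophenyl, which has no hydrogen-bond donors or acceptors, and in this assay compound 3 still gives 50 nM. So a low number on this read-out does not need the donor and acceptor counted on 2-hydroxyphenyl. Compound 2 is reported only as a limit of the assay, not a number: the limit of < 40 nM in this assay, at which 1 of the 3 values shown sits.

The size of the change therefore has only a floor, an at least 1.2-fold higher number from compound 2 to compound 3 (0.09 log units; that floor lies within the scatter), and a real difference between these two groups cannot be claimed. Still open, on these data alone, is how a plain phenyl ring, or a phenyl ring carrying an amine or a carboxylic acid, would behave on that carbon, and whether the chlorine or the hydroxyl group matters at all.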